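This account rests on a few compounds, and the source may have more. Where it says the series, first, only, none or still open, it means among the compounds named here.

In an ADME assay on HepG2 cells (Homo sapiens) for cytotoxicity (on this read-out higher numbers stand for lower toxicity in this test and lower numbers for higher toxicity in this test), compound 1 (`CCCN(CC#Cc1cc2ncnc(Nc3ccc(OCc4cccc(F)c4)c(Cl)c3)c2s1)CCC`) gives 26.5 uM and compound 2 (`CN1CCN(CC#Cc2cc3c(Nc4ccc(OCc5cccc(F)c5)c(Cl)c4)ncnc3s2)CC1`) gives 15 uM, so these two values lie within the scatter of each other. Compound 3 (`COCC#Cc1cc2c(Nc3ccc(OCc4cccc(F)c4)c(Cl)c3)ncnc2s1`) differs from compound 2 by methoxy in place of 4-methylpiperazin-1-yl on a saturated chain carbon bound to a triple-bonded carbon. Going by the values given here, no measured pair covers this change, so the expectation remains tentative. The expected change is a 1.5-fold higher number from compound 2 to compound 3 (0.17 log units; within the scatter), a small rise within the scatter. In this assay the estimated value for compound 3 is 22 uM, with an expected range of 9 uM to 50 uM.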

Compound 3, half-maximal toxic concentration: 9.5 uM
For compound 3 the middle estimate is 2.3-fold (0.36 log units) above the measured one; measured number inside the range.
By their numbers in this assay, from the lowest: compounds 3, 2 and 1 (each within the scatter of the next, the first and the last beyond it).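

Replacing 4-methylpiperazin-1-yl with methoxy on a saturated chain carbon bound to a triple-bonded carbon gives a 1.6-fold lower number from compound 2 to compound 3 (0.20 log units; within the scatter) in this assay. At this place, the six-membered non-aromatic ring and both of its nitrogens can therefore go without a step beyond the scatter in this assay. Nothing at hand explains the result.

Still open, as far as these compounds go, is whether a hydroxyl or a morpholin-4-yl group at this place would also stay within the scatter of compound 3. The same question stands for a longer ether chain such as ethoxy.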